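This account rests on a few compounds, and the source may have more. Where it says the series, first, only, none or still open, it means among the compounds named here.

Measured compounds in the series:
compound 1 `Cc1nc(COc2ccc(/C=C3\SC(=O)NC3=O)cc2)cs1`: 22.9%
compound 2 `O=C1NC(=O)/C(=C/c2ccc(OCCSc3nnc(-c4ccccc4)[nH]3)cc2)S1`: 22.9%
compound 3 `O=C1NC(=O)/C(=C/c2ccc(OCCSc3nnc(Cc4ccccc4)[nH]3)cc2)S1`: 34.4%

In a functional assay on the whole organism (plasma, strain Wistar) with Rattus norvegicus as the target, with a stated time of 15 days, at a dose of 100 mg/kg by the oral route (on this read-out higher numbers stand for a stronger effect at the one dose given and lower numbers for a weaker effect), compound 3 gives 34.4%, the highest of the three numbers; compound 1 and compound 2 both sit lower, each beyond the scatter. Among the measured compounds shown here, the only step measured within one change is a number 11.5 percentage points higher from compound 2 to compound 3 (beyond the scatter), which turns on the group attached to the aromatic carbon of the shared core.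

Compound 4 `Cc1ccc(-c2nnc(SCCOc3ccc(/C=C4\SC(=O)NC4=O)cc3)[nH]2)cc1` is the next compound, differing from compound 3 by 4-methylphenyl in place of benzyl on an aromatic carbon. For the measured compounds named here, no measured step covers this change directly. The closest reference is compound 2, whose phenyl on the same carbon gave 22.9%; the 4-methylphenyl of compound 4 is an aryl group of the same kind with one added carbon, so the reading for compound 4 is expected to fall back toward the value of compound 2 rather than hold the level of compound 3. The expected step is therefore a number 8.4 percentage points lower from compound 3 to compound 4 (within the scatter), downward and only at the edge of the scatter. For compound 4 the estimate in this assay is 26%, with a range of 14% to 38%.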

Compound 4, a percentage reported as activity, at one dose (the size of the read-out at that dose, not a potency): 29.7%
Compound 4: middle estimate off by 3.7 percentage points, on the low side, within the range that was stated.
By their numbers in this assay, from the lowest: compounds 1, 2, 4 and 3 (each within the scatter of the next, the first and the last beyond it).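

In this assay, 4-methylphenyl in place of benzyl on the aromatic carbon of the five-membered aromatic ring gives a number 4.7 percentage points lower from compound 3 to compound 4 (within the scatter), while methyl in place of hydrogen on the same aryl group gives a number 6.8 percentage points higher from compound 2 to compound 4 (within the scatter). Compound 4 therefore cannot be told apart from compound 2 or compound 3 at this position, even though those two are separated by a number 11.5 percentage points higher from compound 2 to compound 3 (beyond the scatter), so this position's three groups do not yet form a resolved order and the benzyl result rests on one clear step alone. Benzyl and 4-methylphenyl match in heavy atoms and ring count, and nothing available explains the readings they give.

As far as these compounds go, it remains open whether a group of another kind on this carbon, such as an amine, a carboxylic acid or a longer chain ending in phenyl, would carry the reading beyond the scatter from compound 3. With one dose only, the series tells of a stronger or weaker effect at that dose and leaves the effect at any other dose open.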